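The source may report more compounds than this note shows. Statements on the series, on what has been measured and on what is new or still open speak of the compounds shown alone.

Working notes on the series. The shared core of compound 1 `Cc1ccc([C@H]2CC(=O)c3ccc(F)cc3O2)cc1` and compound 3 `Cc1ccc([C@H]2CC(=O)c3ccc(C)cc3O2)cc1` carries a pendant ring; compound 2 `Fc1ccc(-c2cc(=S)c3ccc(F)cc3o2)cc1` and the unmeasured compound 4 `Cc1ccc(-c2cc(=S)c3ccc(F)cc3o2)cc1` share a second core, and the difference between the two cores is not broken down here. In an in vitro assay on BTI-TN-5B1-4 cells for inhibition of Amine oxidase [flavin-containing] B (Homo sapiens) (a lower number here means a stronger inhibitor, a higher number a weaker inhibitor), compound 1 gives 150 nM and compound 3 gives 530 nM; the change methyl in place of fluoro on an aromatic carbon made a step of a 3.5-fold higher number from compound 1 to compound 3 (0.55 log units; beyond the scatter). Compound 2 gives 6890 nM in this assay, the highest of the three numbers. Compound 4 carries the change (methyl in place of fluoro on an aromatic carbon), the same kind of change, but here on a six-membered aromatic ring of carbon only, para to a large group, rather than on a fused system meta and para to a fused ring. Given that different place, the step for compound 4 is expected to be a 1.3-fold higher number from compound 2 to compound 4 (0.12 log units; within the scatter), with wide uncertainty. Compound 4 is estimated at 9000 nM, between 3000 nM and 25000 nM.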

Compound 4, half-maximal inhibitory concentration: 1610 nM
Compound 4: the middle estimate sits 5.6-fold (0.75 log units) above what was measured, and the stated range ends above it.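

In this assay, methyl in place of fluoro on an aromatic carbon does not carry over from one core to the other, in either size or direction: the same change on two cores in this assay, a 3.5-fold higher number (0.55 log units; beyond the scatter) from compound 1 to compound 3 and a 4.3-fold lower number (0.63 log units; beyond the scatter) from compound 2 to compound 4, 15-fold (1.18 log units) apart, beyond the scatter of two such steps. The new step is a 4.3-fold lower number from compound 2 to compound 4 (0.63 log units; beyond the scatter), so the change that raises the number on the core of compound 1 lowers it on the core of compound 2. The two steps also differ in where the change sits, so this pair does not show whether the core or the place of the change accounts for the reversal, and one pair per core gives no rule for the series.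

Still open, on these data alone, is whether the change gives matching steps when it sits at the same place on both cores. Also open, as far as these compounds go, is how an amine or a methoxy group at that carbon would compare with fluoro and methyl.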